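The source may hold more compounds than are shown below. What is called first, only, known or untested is meant among the compounds shown, and "the series" means these compounds.

Measured so far in an in vitro ADME assay on microsomes from liver (Homo sapiens) for pharmacokinetics, read by LC-MS, with a stated time of 10 min, tested at 1 uM; on this read-out higher numbers stand for fast clearance and lower numbers for slow clearance:
Compound 1 `Cc1ccc(NC(=O)[C@H]2CN(C)C[C@@H]2c2ccc(/C=C/C(=O)Nc3ccccc3N)cc2)cc1` gives 15 mL/min/kg
Compound 2 `CN1C[C@H](C(=O)Nc2ccc(F)cc2F)[C@@H](c2ccc(/C=C/C(=O)Nc3ccccc3N)cc2)C1` gives 12 mL/min/kg

For the measured compounds named here, of these two numbers, the one for compound 2 is 12 mL/min/kg and lies within the scatter of compound 1. The next compound to be read is compound 3 `CN1C[C@H](C(=O)Nc2ccc(Cl)cc2F)[C@@H](c2ccc(/C=C/C(=O)Nc3ccccc3N)cc2)C1`, which differs from compound 2 in one place. The change is chloro in place of fluoro on an aromatic carbon and amounts to chloro in place of fluoro on an aromatic carbon, para to a large group and meta to a fluoro group. In the longer view, 2,4-difluorophenyl becomes 4-chloro-2-fluorophenyl.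

Going by the values given here, only one measured step bears on this, and it alters the same phenyl group on the amide-type nitrogen: a 1.3-fold lower number from compound 1 to compound 2 (0.10 log units; within the scatter) with 2,4-difluorophenyl in place of 4-methylphenyl. Among the compounds with values here, no measured compound yet carries chloro on this group, so the expectation rests on that single step. No step beyond the scatter is expected in this assay, and the estimated step is a 1.1-fold higher number from compound 2 to compound 3 (0.03 log units; within the scatter) in this read-out. Compound 3 is estimated at 13 mL/min/kg with an expected range of 7 mL/min/kg to 24 mL/min/kg on this measure.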

Compound 3, clearance: 11 mL/min/kg
Compound 3: middle estimate off by 1.2-fold (0.07 log units), on the high side, and the stated range covers the measured number.
By their numbers in this assay, from the lowest: compounds 3, 2 and 1 (each within the scatter of the next).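

In this assay, the place para to a large group on this phenyl ring now carries a second kind of substituent, and the step reads a 1.1-fold lower number from compound 2 to compound 3 (0.04 log units; within the scatter), so chloro in place of fluoro leaves the clearance number within the usual scatter. The wider comparison with the 4-methylphenyl group reads a 1.4-fold lower number from compound 1 to compound 3 (0.13 log units; within the scatter), which extends the picture to all three groups on the amide-type nitrogen: 4-methylphenyl, 2,4-difluorophenyl and 4-chloro-2-fluorophenyl give numbers that cannot be told apart in this read-out. Nothing available explains why these changes leave the number within the scatter.

The compounds shown leave open whether any other substituent at this place, such as a methoxy group, a nitrile or a dimethylamino group, would produce a step beyond the scatter. They also leave open whether chloro in place of fluoro would read the same without the remaining fluoro group on the ring, and whether a pyridine or a cyclohexyl group in place of the whole phenyl ring would shift the clearance number.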